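Working notes: 3-hydroxyphenyl to 4-fluorophenyl on a shared core

This account rests on a few compounds, and the source may have more. Where it says the series, first, only, none or still open, it means among the compounds named here.

Of the compounds shown here, three in this set have been measured and one has not. Compound 1 `Cc1ccc(S(=O)(=O)c2nc3ccccc3nc2Nc2cccc(O)c2)cc1` gives 1690 nM in a functional assay on PC-3 cells (Homo sapiens) for cytotoxicity, read by MTT assay, with a stated time of 72 h; a higher number here means a weaker inhibitor, a lower number a stronger inhibitor. Compound 2 `Cc1ccc(S(=O)(=O)c2nc3ccccc3nc2Nc2ccc(F)cc2)cc1` gives 13100 nM in this assay. Compound 3 `O=S(=O)(c1ccc(Br)cc1)c1nc2ccccc2nc1Nc1cccc(O)c1` gives 1700 nM in this assay. Compound 4 `O=S(=O)(c1ccc(Br)cc1)c1nc2ccccc2nc1Nc1ccc(F)cc1` has not yet been measured in this assay.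

Compound 2 differs from compound 1 by 4-fluorophenyl in place of 3-hydroxyphenyl on a nitrogen on an aromatic ring and this change gave a 7.8-fold higher number from compound 1 to compound 2 (0.89 log units; beyond the scatter). The two cores on which this change is made differ as follows: bromo in place of methyl on an aromatic carbon and that difference gave a 1.0-fold higher number from compound 1 to compound 3 (0.00 log units; within the scatter), so the two cores sit at essentially the same level in this assay.

Compound 4 differs from compound 3 by 4-fluorophenyl in place of 3-hydroxyphenyl on a nitrogen on an aromatic ring. The place is described in the same words for both pairs, so this is the same change made a second time, on a core that differs from the first only in the way described above. With a single earlier instance to rest on, the expectation is that the step repeats in size and direction; the expected step is a 7.6-fold higher number from compound 3 to compound 4 (0.88 log units; beyond the scatter), because the same change gave a 7.8-fold higher number from compound 1 to compound 2 (0.89 log units; beyond the scatter). Since the core change itself was flat, no adjustment is made for it.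

Compound 4 is therefore estimated at 13000 nM, with a likely span from 5000 nM to 35000 nM. The span is wide. Within the data shown here, only one prior measurement of this change exists, and the earlier step of a 7.8-fold higher number from compound 1 to compound 2 (0.89 log units; beyond the scatter) was itself only modest beyond the scatter.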

Compound 4, half-maximal inhibitory concentration: 9160 nM
For compound 4 the middle estimate is 1.4-fold (0.15 log units) above the measured one; the range from low to high includes it.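

In this assay, 4-fluorophenyl in place of 3-hydroxyphenyl on the core of compound 3 again gives a higher number, a 5.4-fold higher number from compound 3 to compound 4 (0.73 log units; beyond the scatter), and the step carries over from the core of compound 1 in direction and, within the scatter, in size: the same change on two cores in this assay, a 7.8-fold higher number (0.89 log units; beyond the scatter) from compound 1 to compound 2 and a 5.4-fold higher number (0.73 log units; beyond the scatter) from compound 3 to compound 4, 1.4-fold (0.16 log units) apart, within the scatter of two such steps. The bromo-for-methyl difference is also within the scatter with 4-fluorophenyl on the nitrogen, a 1.4-fold lower number from compound 2 to compound 4 (0.16 log units; within the scatter), matching what was seen with 3-hydroxyphenyl: the same change on two cores in this assay, a 1.0-fold higher number (0.00 log units; within the scatter) from compound 1 to compound 3 and a 1.4-fold lower number (0.16 log units; within the scatter) from compound 2 to compound 4, 1.4-fold (0.16 log units) apart, within the scatter of two such steps. Among these compounds, this shows that the two changes behave independently across these four compounds, but it covers only two cores that differ in one place, and it does not show how the step behaves on any other core or whether the hydroxy group, the fluoro group or their places on the ring account for it.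

The compounds shown leave open how 3-fluorophenyl and 4-hydroxyphenyl on the same nitrogen would compare, which would separate the group from its place on the ring. Also open, on these data alone, is what an amine or a carboxylic acid on that phenyl ring would give, and whether a chloro or methoxy group in place of bromo on the core would stay equally flat.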